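Trifluoromethoxy for trifluoromethyl on a narrow set of values

This account rests on a few compounds, and the source may have more. Where it says the series, first, only, none or still open, it means among the compounds named here.

Values in a functional assay on DU-145 cells (Homo sapiens) for antiproliferative activity, read by propidium iodide staining, with a stated time of 96 h (a lower number here means a stronger inhibitor, a higher number a weaker inhibitor), are these:

- compound 1 `CC(O)(CSc1cccc(OC(F)(F)F)c1)C(=O)Nc1cccc(S(F)(F)(F)(F)F)c1` gives 25000 nM
- compound 2 `CC(O)(CS(=O)(=O)c1cccc(S(F)(F)(F)(F)F)c1)C(=O)Nc1ccc(S(F)(F)(F)(F)F)cc1` gives 34000 nM
- compound 3 `CC(O)(CS(=O)(=O)c1cccc(C(F)(F)F)c1)C(=O)Nc1ccc(S(F)(F)(F)(F)F)cc1` gives 31900 nM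

Compound 3 lies within the scatter of both other compounds, so it holds no distinct place among these numbers. Compound 4 `CC(O)(CS(=O)(=O)c1cccc(OC(F)(F)F)c1)C(=O)Nc1ccc(S(F)(F)(F)(F)F)cc1` carries trifluoromethoxy in place of trifluoromethyl on an aromatic carbon and is otherwise the same. Going by the values given here, the measured step of a 1.1-fold lower number from compound 2 to compound 3 (0.03 log units; within the scatter) also exchanges a group on an aromatic carbon and is the only one bearing on this change. Compound 1 also carries trifluoromethoxy but differs elsewhere too. No shift beyond the scatter is therefore expected in this assay for this exchange. The expected step is a 1.1-fold lower number from compound 3 to compound 4 (0.03 log units; within the scatter) and no larger. Compound 4 is estimated at 30000 nM within an expected range of 15000 nM to 60000 nM once it is measured.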

Compound 4, half-maximal inhibitory concentration: 26500 nM
Beside the measured number, compound 4's estimate is 1.1-fold (0.05 log units) above it; measured number inside the range.
By their numbers in this assay, from the lowest: compounds 1, 4, 3 and 2 (each within the scatter of the next).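

In this assay, the exchange at this position gives a 1.2-fold lower number from compound 3 to compound 4 (0.08 log units; within the scatter), so trifluoromethoxy and trifluoromethyl read alike on this aromatic carbon. The group of 6 heavy atoms in compound 2 gives a 1.3-fold lower number from compound 2 to compound 4 (0.11 log units; within the scatter), which places all three groups tested here within the scatter of one another. Nothing available bears on why these numbers stay so close. From the compounds shown here alone, whether an amine, a carboxylic acid or a longer chain at this position would move the number remains open. Also open, going by these compounds, is whether the same exchange would read alike on another core.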